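A few compounds are considered here, and "the series" means these few. Any claim that something is new, unique, unknown or untested is made for them only; others in the source may bear on it.

In an ADME assay on L6 cells (Rattus norvegicus) for cytotoxicity (on this read-out higher numbers stand for weaker inhibition and lower numbers for stronger inhibition), compound 1 (`O=C(CN1CCCCC1)OC1CC2(N3CCCCC3)CC(c3ccccc3)C1C(c1ccccc1)C2`) gives 60400 nM; > 184000 nM (2 entries). One of these entries is a limit of the assay, not a number. Among the compounds with values here, compound 2 (`O=C(CCN1CCCCC1)OC1CC2(N3CCCCC3)CC(c3ccccc3)C1C(c1ccccc1)C2`) gives 54600 nM, the only single number available in this assay. Compound 3 (`O=C(CCN1CCC(O)CC1)OC1CC2(N3CCCCC3)CC(c3ccccc3)C1C(c1ccccc1)C2`) carries hydroxy in place of hydrogen on a saturated ring carbon of compound 2, changing 2-(piperidin-1-yl)ethyl to 2-(4-hydroxypiperidin-1-yl)ethyl: hydroxy in place of hydrogen on a saturated ring carbon. Within the data shown here, no measured pair shows this change. The estimated step of a 1.5-fold higher number from compound 2 to compound 3 (0.17 log units; within the scatter) is small, expected toward weaker inhibition and within the scatter. For compound 3, the expected value is 80000 nM, with an estimated range of 35000 nM to 190000 nM.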

Compound 3, half-maximal inhibitory concentration: 28500 nM
The estimate for compound 3 lay 2.8-fold (0.45 log units) above the measured number, outside the stated range (below it).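

In this assay, hydroxy in place of hydrogen on a saturated ring carbon, three ring bonds from the ring nitrogen, gives a 1.9-fold lower number from compound 2 to compound 3 (0.28 log units; within the scatter), so this first step at the position cannot be told from the scatter. Single numbers in this assay carry limited weight, as a close relative shows: the several entries of compound 1 in this assay, 60400 nM; > 184000 nM (2 entries). One of those entries is a limit of the assay, not a number.

Going by these compounds, whether an amine or a carboxylic acid on this ring carbon would read differently remains open. So does whether hydroxy gives a similar step on the (piperidin-1-yl)methyl chain of compound 1.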